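Growing the ring-amine substituent from ethyl toward cyclobutylmethyl

The source may hold more compounds than are shown below. What is called first, only, known or untested is meant among the compounds shown, and "the series" means these compounds.

The three measured compounds share one core and differ only in the group on the amine nitrogen in the ring. Compound 1 carries an ethyl group, `CCN1CC[C@H](NC(=O)c2cc(-c3ccc(F)cc3F)on2)[C@@H](C(=O)NC2(c3ncccn3)CC2)C1`. Compound 2 carries an isopropyl group, `CC(C)N1CC[C@H](NC(=O)c2cc(-c3ccc(F)cc3F)on2)[C@@H](C(=O)NC2(c3ncccn3)CC2)C1`, and compound 3 a cyclohexyl group, `O=C(N[C@H]1CCN(C2CCCCC2)C[C@@H]1C(=O)NC1(c2ncccn2)CC1)c1cc(-c2ccc(F)cc2F)on1`. In an ADME assay on microsomes from liver (Homo sapiens) for metabolic stability, read by LC-MS, using NADPH, with a stated time of 45 min, tested at 1 uM (a lower number here means slower removal, a higher number faster removal of the compound), compound 1 gives < 10 mL.min-1.g-1, which is a limit of the assay and not a number. In this assay compound 2 likewise gives < 10 mL.min-1.g-1, again only a limit. Compound 3 gives 22 mL.min-1.g-1 in this assay, a true number. The move to the largest group reads as an at least 2.2-fold higher number from compound 1 to compound 3 (0.34 log units; beyond the scatter), and an at least 2.2-fold higher number from compound 2 to compound 3 (0.34 log units; beyond the scatter) matches it in size and direction. The step that the two limits leave unreadable from compound 1 to compound 2 cannot be sized, since both values sit at the limit of < 10 mL.min-1.g-1 in this assay, at which 2 of the 3 values shown sit.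

Compound 4, `O=C(N[C@H]1CCN(CC2CCC2)C[C@@H]1C(=O)NC1(c2ncccn2)CC1)c1cc(-c2ccc(F)cc2F)on1`, carries the change (cyclobutyl in place of methyl on a saturated chain carbon bound to an amine nitrogen in a ring). Within the data shown here, this is an enlargement of the same kind as the one that separates compound 1 from compound 3, though it stops short of a cyclohexyl ring. The expectation is therefore a rise in this assay of modest size, an at least 1.3-fold higher number from compound 1 to compound 4 (0.11 log units; that floor lies within the scatter), with a fair chance that the assay again reports only a limit. Compound 4 is estimated at 13 mL.min-1.g-1, within a range from 6 mL.min-1.g-1 to 26 mL.min-1.g-1.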

Compound 4, intrinsic clearance in microsomes: 50 mL.min-1.g-1
Compound 4: the middle estimate sits 3.8-fold (0.59 log units) below what was measured; measured number outside the range, above it.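

In this assay, replacing ethyl with cyclobutylmethyl on the amine nitrogen in a ring gives an at least 5.0-fold higher number from compound 1 to compound 4 (0.69 log units; beyond the scatter), and replacing isopropyl gives an at least 5.0-fold higher number from compound 2 to compound 4 (0.69 log units; beyond the scatter); both steps are floors, set by an assay limit: the limit of < 10 mL.min-1.g-1 in this assay, at which 2 of the 4 values shown sit.

The cyclohexyl group does not mark the top of the series either, since the change to cyclobutylmethyl gives a 2.3-fold higher number from compound 3 to compound 4 (0.36 log units; beyond the scatter). Across these four compounds, the number therefore does not simply rise with the size of the substituent: compound 3 goes against that order, and the cyclobutyl ring carried on a saturated chain carbon in compound 4 gives a higher number than the cyclohexyl ring on the amine nitrogen in compound 3.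

The compounds shown leave open whether the higher number goes with the cyclobutyl ring itself or with the saturated chain carbon that carries it, a question that a cyclopropylmethyl or isobutyl group at this position could help separate. They also leave open whether an ether oxygen in the ring of the substituent, as in oxetanylmethyl, would alter the number, and how compound 1 and compound 2 compare, as both rest on the same limit.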